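Notes on the step from compound 3 to compound 4

The compounds below may be only part of what the source reports. "The series", "measured", "known", "first", "only" and "open" are said of these compounds alone.

Measured so far in a functional assay on MCF7 cells (Homo sapiens) for inhibition, read by fluorescence, with a stated time of 72 h; on this read-out lower numbers stand for stronger inhibition and higher numbers for weaker inhibition

- compound 1 `N=C(N)Nc1nc(N)nc2c1ncn2CCN` gives > 100000 nM
- compound 2 `CC[C@H](CO)Nc1nc(NC(=N)N)c2ncn(C(C)C)c2n1` gives 4500 nM
- compound 3 `CC(C)[C@H](CO)Nc1nc(NC(=N)N)c2ncn(C(C)C)c2n1` gives 10500 nM

The entry for compound 1 is a limit of this assay and not a number.

Of the two numbers, compound 3 stands highest (10500 nM) and compound 2 is nearest (4500 nM). Among the measured compounds shown here, the one measured step is a 2.3-fold higher number from compound 2 to compound 3 (0.37 log units; beyond the scatter) and it is modest; it puts a methyl in place of hydrogen on a saturated chain carbon bound to two saturated chain carbons.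

Compound 4 `CC(C)n1cnc2c(NC(=N)N)nc(N3CCC[C@@H]3CO)nc21` keeps the shared core. In it, 2-(hydroxymethyl)pyrrolidin-1-yl stands in place of (1-(hydroxymethyl)-2-methylpropyl)amino on an aromatic carbon (2-(hydroxymethyl)pyrrolidin-1-yl in place of (1-(hydroxymethyl)-2-methylpropyl)amino on an aromatic carbon) and brings one five-membered non-aromatic ring. For the measured compounds named here, no measured step covers such a ring, so the evidence is thin. Going by the values given here, the only guide is a 2.3-fold higher number from compound 2 to compound 3 (0.37 log units; beyond the scatter) within the group that leaves, which suggests a modest step toward a higher number in this assay as the expectation, with the direction uncertain. The expected change is a 1.7-fold higher number from compound 3 to compound 4 (0.23 log units; within the scatter) and no more than that. The estimate for compound 4 is 18000 nM with an expected range from 6000 nM to 55000 nM in this read-out.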

Compound 4, half-maximal inhibitory concentration: 20400 nM
For compound 4 the middle estimate is 1.1-fold (0.05 log units) below the measured one; the measured number falls inside the stated range.
By their numbers in this assay, from the lowest: compound 2; then compounds 3 and 4 (each within the scatter of the next). At a limit, above all of these: compound 1.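

In this assay, the new five-membered non-aromatic ring at this position, on the aromatic carbon between two ring nitrogen atoms, gives a 1.9-fold higher number from compound 3 to compound 4 (0.29 log units; within the scatter), so 2-(hydroxymethyl)pyrrolidin-1-yl cannot be told apart from (1-(hydroxymethyl)-2-methylpropyl)amino in this read-out. Measured against (1-(hydroxymethyl)propyl)amino, the same ring gives a 4.5-fold higher number from compound 2 to compound 4 (0.66 log units; beyond the scatter), a modest step that is larger than the one seen before with the added methyl and leaves compound 2 with the lowest number of the three compounds carrying a hydroxymethyl side group. Both changes away from compound 2 at this position therefore lead to a higher number, with neither compound 3 nor compound 4 going against that, but nothing at hand gives a reason for these steps.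

From the compounds shown here alone, it remains open whether the hydroxymethyl group matters on the ring at all, as a plain pyrrolidin-1-yl or a carboxylic acid in its place would show. Ring size and chain length are also unsettled: a piperidin-1-yl group or a longer hydroxyalkyl amino chain might take the number either way from that of compound 2.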